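A few compounds are considered here, and "the series" means these few. Any claim that something is new, unique, unknown or untested is made for them only; others in the source may bear on it.

Series notes, a functional assay on HCT-15 cells (Homo sapiens) for cytotoxicity, read by MTT assay, with a stated time of 2 days; on this read-out lower numbers stand for stronger inhibition and higher numbers for weaker inhibition.

Compound 1 `O=c1[nH]c(-c2cccc3ccccc23)nc2ccc(N3CCCCC3)cc12` gives 2240 nM in this assay. Compound 3 `CCN(CC)c1ccc2nc(-c3cccc4ccccc34)[nH]c(=O)c2c1` gives 3210 nM in this assay. Among the compounds with values here, the one measured step, a 1.4-fold higher number from compound 1 to compound 3 (0.16 log units; within the scatter), concerns a different position of the shared core and does not touch the present comparison. Compound 2 `Cc1ccc2c(=O)[nH]c(-c3cccc(OC(F)(F)F)c3)nc2c1` returns only a limit in this assay, > 50000 nM, so its value is not a number. Among the three values shown, compound 2 sits at the limit of > 50000 nM in this assay, at which 1 of the 3 values shown sits, whereas compound 1 and compound 3 stand as numbers well inside the measured range.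

Compound 4 `Cc1ccc2c(=O)[nH]c(-c3cccc(F)c3)nc2c1` differs from compound 2 only by fluoro in place of trifluoromethoxy on an aromatic carbon. Within the data shown here, no measured step involves fluoro or trifluoromethoxy, or this aromatic carbon, so no step size can be carried over. Compound 2 itself gives only a limit, so the step to compound 4 cannot be placed as a number in either direction. Both measured numbers come from compound 1 and compound 3, whose structures differ from compound 4 in more than one place. Compound 4 is therefore expected to sit near the same limit. The step that the limit leaves unreadable from compound 2 to compound 4 is expected to be small. The estimate for compound 4 is 60000 nM, ranging from 15000 nM to 250000 nM, with a limit again the likelier outcome.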

Compound 4, half-maximal inhibitory concentration: 14400 nM
Beside the measured number, compound 4's estimate is 4.2-fold (0.62 log units) above it; the measured number lies below the stated range.
By their numbers in this assay, from the lowest: compounds 1 and 3 (each within the scatter of the next); then compound 4. At a limit, above all of these: compound 2.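

In this assay, within the data shown here, fluoro in place of trifluoromethoxy on this aromatic carbon gives an at least 3.4-fold lower number from compound 2 to compound 4 (0.54 log units; beyond the scatter), the first step that lies beyond the scatter. The earlier step, at a different position of the shared core, stayed within the scatter, whereas this aromatic carbon responds to the group it carries, with five heavy atoms leaving and one entering. Compound 2 stands at a limit and not at a number, so the step fixes a smallest size and no exact size: the limit of > 50000 nM in this assay, at which 1 of the 4 values shown sits.

Only fluoro and trifluoromethoxy are shown at this aromatic carbon, and it remains open how a methoxy group, a chlorine atom, an amine or a carboxylic acid there would read, or a plain hydrogen. Among these compounds, also open is how the core of compound 4 relates to the core of compound 1 and compound 3, as no pair differing in one place links them and the effect of fluoro on those cores cannot be read.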